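Trimming One Group of Compound 3 to Trifluoromethyl

The compounds below may be only part of what the source reports. "The series", "measured", "known", "first", "only" and "open" are said of these compounds alone.

Compound 1 `CC(O)(CSc1ccc(S(F)(F)(F)(F)F)cc1)C(=O)Nc1ccc([N+](=O)[O-])cc1C(F)(F)F`: 13100 nM
Compound 2 `CC(O)(CSc1cccc(S(F)(F)(F)(F)F)c1)C(=O)Nc1ccc([N+](=O)[O-])cc1C(F)(F)F`: 17500 nM
Compound 3 `CC(O)(CSc1ccc(S(F)(F)(F)(F)F)cc1)C(=O)Nc1cccc(S(F)(F)(F)(F)F)c1`: 13100 nM

All three values come from a functional assay on CWR22R cells (Homo sapiens) for antiproliferative activity, read by propidium iodide staining, with a stated time of 96 h; a higher number here means a weaker inhibitor, a lower number a stronger inhibitor. There, compound 3 gives 13100 nM, level with compound 1 at 13100 nM, and compound 2 at 17500 nM lies within the usual scatter of both.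

The next compound, compound 4 `CC(O)(CSc1ccc(C(F)(F)F)cc1)C(=O)Nc1cccc(S(F)(F)(F)(F)F)c1`, keeps most of compound 3 but exchanges one group on an aromatic carbon, para to a large group, for trifluoromethyl: a group of 4 heavy atoms (1 carbon, 3 fluorine; no ring) in place of a group of 6 heavy atoms (5 fluorine, 1 sulfur; no ring), on an aromatic carbon.

Going by the values given here, no measured pair here differs in one place alone, so the data give no direct guide to this exchange. The expectation rests only on how closely the three measured compounds agree, with compound 3 at 13100 nM, so no step beyond the scatter is expected in this assay. The expected change is small: a 1.1-fold higher number from compound 3 to compound 4 (0.06 log units; within the scatter). Compound 4 is estimated at 15000 nM, with an expected range of 7000 nM to 30000 nM.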

Compound 4, half-maximal inhibitory concentration: 26900 nM
Beside the measured number, compound 4's estimate is 1.8-fold (0.25 log units) below it, and the stated range covers the measured number.
By their numbers in this assay, from the lowest: compounds 1, 3, 2 and 4 (each within the scatter of the next, the first and the last beyond it).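

Going by these compounds alone, this is the first pair here that differs in one place alone, so the group on this aromatic carbon, para to a large group, can now be judged directly. In this assay trifluoromethyl in place of the group of 6 heavy atoms (5 fluorine, 1 sulfur) gives a 2.1-fold higher number from compound 3 to compound 4 (0.31 log units; beyond the scatter) in this pair, a modest step, but one that lies beyond the usual scatter. So this position does respond to the exchange, and of these two groups the larger one gives the lower number. No measurement at hand speaks to the cause of this step.

On these data alone, whether the same exchange would act alike at the other end of the molecule remains open. So does the outcome at this position with a chlorine atom, a methoxy group or a nitrile.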